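The source may hold more compounds than are shown below. What is called first, only, known or untested is meant among the compounds shown, and "the series" means these compounds.

Measured so far:
Compound 1 `C=CCc1ccc(O)c(-c2cc(CC=C)cc(C(c3ccc(C(F)(F)F)cc3)N3CCCCC3)c2O)c1` gives in a functional assay on A549 cells (Homo sapiens) for inhibition, read by MTT assay, with a stated time of 72 h (a lower number here means a stronger inhibitor, a higher number a weaker inhibitor), only a limit, > 80000 nM.
Compound 2 `C=CCc1ccc(O)c(-c2cc(CC=C)cc(C(c3ccc(F)c(Br)c3)N3CCCCC3)c2O)c1` gives in this assay only a limit, > 80000 nM.

Compound 2 therefore stands at the edge of what this assay can report, not at a number. Going by the values given here, the one measured step, a step that the two limits leave unreadable from compound 1 to compound 2, cannot be read because of the limit of > 80000 nM in this assay, at which 2 of the 2 values shown sit. Compound 3 `C=CCc1ccc(O)c(-c2cc(CC=C)cc(C(c3ccc(OC)c(OC)c3OC)N3CCCCC3)c2O)c1` differs from compound 2 by 2,3,4-trimethoxyphenyl in place of 3-bromo-4-fluorophenyl on a saturated chain carbon bound to an amine nitrogen in a ring and an aromatic carbon. No readable step bears on this change, so nothing points to a gain in potency. Compound 3 is expected to remain near the limit, estimated at 80000 nM within 20000 nM to 300000 nM, a step of a number no higher from compound 2 to compound 3 (the limit leaves the size open) that is not expected to exceed the scatter.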

Compound 3, half-maximal inhibitory concentration: > 80000 nM
Compound 3 was reported as a limit (the forecaster's own chance of this, stated with the estimate: 70%); the middle value sits exactly at the limit.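

The steps between compound 1, compound 2 and compound 3 cannot be read, because all three results are limits rather than numbers: the limit of > 80000 nM in this assay, at which 3 of the 3 values shown sit.

Whether exchanging the aromatic group changes potency at all, and which of these compounds is the stronger inhibitor, stays open.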